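Removing a methoxy: from compound 3 to compound 4

The source may hold more compounds than are shown below. What is called first, only, known or untested is meant among the compounds shown, and "the series" means these compounds.

Of the compounds shown here, three have been measured in a functional assay on FM3A cells (Mus musculus) for inhibition, read by cell counting, with a stated time of 2 days; a lower number here means a stronger inhibitor, a higher number a weaker inhibitor. Compound 1 `CCOc1ccc(-c2nn3cc(-c4cccc(N)c4)nc3s2)cc1` gives only a limit of the assay, >= 250000 nM. Compound 2 `C=C(Br)C(=O)Nc1cccc(-c2cn3nc(-c4ccccc4)sc3n2)c1` gives 900 nM. Compound 3 `COc1cccc(-c2nn3cc(-c4cccc(N)c4)nc3s2)c1` gives 29000 nM, the higher of the two numbers in this assay. The difference between compound 3 and compound 2 is beyond the scatter of repeated measurements. Compound 4 `Nc1cccc(-c2cn3nc(-c4ccccc4)sc3n2)c1` has not yet been measured. It differs from compound 3 in one place (hydrogen in place of methoxy on an aromatic carbon), that is, hydrogen in place of methoxy on an aromatic carbon, the one that is meta to a large group. For the measured compounds named here, no measured pair in this set shows the effect of that change on its own, so the expectation rests on compound 3 alone. The step is expected to be small, a 1.2-fold lower number from compound 3 to compound 4 (0.06 log units; within the scatter), not beyond the scatter, with no clear direction. In this assay compound 4 is therefore estimated at 25000 nM, within a range from 7000 nM to 90000 nM.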

Compound 4, half-maximal inhibitory concentration: 14000 nM
Compound 4: middle estimate off by 1.8-fold (0.25 log units), on the high side, and the stated range covers the measured number.
By their numbers in this assay, from the lowest: compound 2; then compound 4; then compound 3. At a limit, above all of these: compound 1.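

Hydrogen in place of methoxy on the aromatic carbon meta to a large group gives a 2.1-fold lower number from compound 3 to compound 4 (0.32 log units; beyond the scatter) in this assay, so the methoxy is not needed at this position for the activity seen, and its loss brings a modest gain. On the nitrogen on the aromatic ring the same kind of change counts for much more, since hydrogen in place of (1-bromoethenyl)carbonyl gives a 16-fold higher number from compound 2 to compound 4 (1.19 log units; beyond the scatter), a large step in the opposite direction. Hydrogen in place of ethoxy gives an at least 17-fold lower number from compound 1 to compound 4 (1.25 log units; beyond the scatter), a large step that rests on a limit and not on a number: the limit of >= 250000 nM in this assay, at which 1 of the 4 values shown sits.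

The compounds shown leave open whether a hydroxyl or a chlorine on that aromatic carbon would move the number the same way. They also leave open whether a plain acetyl on the nitrogen, without the bromine, would keep the lower number of compound 2.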